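The source may report more compounds than this note shows. Statements on the series, on what has been measured and on what is new or still open speak of the compounds shown alone.

Measured so far in a functional assay on the whole organism (strain CF-1) with Mus musculus as the target, in the writhing test, with a stated time of 15 min; a higher number here means that more compound is needed for the effect, a lower number that less compound is needed: compound 1 `O=C(/N=C1\NC2(CCCCO2)CCS1)c1ccccc1` gives 5 mg/kg, and compound 3 `N#Cc1ccc(C(=O)/N=C2\NC3(CCCCO3)CCS2)cc1` gives 60 mg/kg. Compound 2 `O=C(/N=C1\NC2(CCCCO2)CCS1)c1cccc(C(F)(F)F)c1` reaches (the limit of > 200 mg/kg in this assay, at which 1 of the 3 values shown sits), giving > 200 mg/kg as a limit rather than a number. Compound 1 has the lowest number of the two measured, compound 3 being the nearest.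

Both steps away from compound 1 add a group to the phenyl: an at least 40-fold higher number from compound 1 to compound 2 (1.60 log units; beyond the scatter) and a 12-fold higher number from compound 1 to compound 3 (1.08 log units; beyond the scatter).

Compound 4 `O=C(/N=C1\NC2(CCCCO2)CCS1)c1ccco1` differs from compound 1 by furan-2-yl in place of phenyl on a carbonyl carbon. Neither measured step exchanges the ring itself, so both bear on this change only loosely; the new ring carries none of the added groups behind those steps. A step of modest size in this assay is expected, a 2.0-fold higher number from compound 1 to compound 4 (0.30 log units; within the scatter), direction open. Compound 4 is estimated at 10 mg/kg, between 3 mg/kg and 40 mg/kg.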

Compound 4, dose for half-maximal effect: 42 mg/kg
Compound 4: middle estimate off by 4.2-fold (0.62 log units), on the low side; measured number outside the range, above it.
By their numbers in this assay, from the lowest: compound 1; then compounds 4 and 3 (each within the scatter of the next). At a limit, above all of these: compound 2.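

In this assay, exchanging the ring itself, with no added group, gives an 8.4-fold higher number from compound 1 to compound 4 (0.92 log units; beyond the scatter). Sensitivity at this carbonyl carbon therefore extends beyond the added groups on the phenyl, and in all the single changes shown here, the phenyl of compound 1 has not been replaced without a rise in the number. Nothing listed bears on the cause of this step.

Open, from the compounds shown here alone, is whether thiophen-2-yl, cyclohexyl or a phenyl carrying a methoxy group would stay close to compound 1. Also open, going by these compounds, is how changes to the shared core would read.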